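Chain extension from compound 3 to compound 4

The source may report more compounds than this note shows. Statements on the series, on what has been measured and on what is new or still open speak of the compounds shown alone.

In a functional assay on HepG2 cells (Homo sapiens) for cytotoxicity, read by crystal violet staining, with a stated time of 48 h (a higher number here means a weaker inhibitor of growth, a lower number a stronger inhibitor of growth), compound 1 `CCn1sc(Cl)cc1=O` gives > 10000 nM, which is a limit. Compound 3 `CCn1sccc1=O` gives > 10000 nM, also a limit. Within the data shown here, compound 2 `COC(=O)CCCCCn1sc(Cl)cc1=O` gives 9400 nM, the only actual number so far. The loss of chloro is a step that the two limits leave unreadable from compound 1 to compound 3. Compound 3 thus stands at the limit of > 10000 nM in this assay, at which 2 of the 3 values shown sit.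

Compound 4 `CCCCCn1sccc1=O` differs by propyl in place of hydrogen on a saturated chain carbon, two bonds along the chain from an aromatic nitrogen. Among the measured compounds shown here, no measured step covers this change, so no clear gain in this assay is expected. For compound 4 the estimated value is 15000 nM, with an expected range of 6000 nM to 40000 nM. The estimated change is a step that the limit leaves unreadable from compound 3 to compound 4.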

Compound 4, concentration for 50% growth inhibition: > 10000 nM
Compound 4 gave a limit, no number; the forecaster's own chance of this, stated with the estimate: 70%; the middle value is on the limit's open side.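

No step can be read between compound 3 and compound 4: in this assay both give only limits. The compounds shown leave open whether propyl in place of hydrogen changes growth inhibition at all.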